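The source may hold more compounds than are shown below. What is called first, only, known or untested is meant among the compounds shown, and "the series" means these compounds.

Measured in a functional assay on HeLa cells (Homo sapiens) for cytotoxicity, read by MTT assay, with a stated time of 72 h, tested at 100 uM; on this read-out higher numbers stand for more inhibition of growth at the one concentration tested and lower numbers for less inhibition of growth:

compound 1 `N/C(=N\NC(=S)N1CCCCCC1)c1ccccn1`: 88.7%
compound 2 `Cc1ccnc(/C(N)=N/NC(=S)N2CCSCC2)c1`: 91.6%
compound 3 `N/C(=N\NC(=S)N1CCSCC1)c1ccccn1`: 88.7%

Compound 1 and compound 3 share the thiosemicarbazide-amidine arrangement but carry different saturated rings on the thiocarbonyl; the difference between the two cores is not broken down here. At the digits given, compound 1 and compound 3 stand level in this assay, and compound 2 is within the scatter of both, so no order among the three can be read.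

Within the core of compound 3, the change methyl in place of hydrogen on an aromatic carbon gives compound 2, with the step of a number 2.9 percentage points higher from compound 3 to compound 2 (within the scatter), which the scatter covers.

Compound 4 `Cc1ccnc(/C(N)=N/NC(=S)N2CCCCCC2)c1` is not yet measured. Among the measured compounds shown here, it arises from compound 1 by methyl in place of hydrogen on an aromatic carbon, the same change as the one from compound 3 to compound 2, made at a place described in the same words. Because that earlier step was a number 2.9 percentage points higher from compound 3 to compound 2 (within the scatter), the step from compound 1 to compound 4 in this assay is expected to be of the same small size, a number 1.8 percentage points higher from compound 1 to compound 4 (within the scatter). Compound 4 is therefore estimated at 90.5%, with a range from 82% to 97%.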

Compound 4, percent growth inhibition at one concentration: 91.6%
Beside the measured number, compound 4's estimate is 1.1 percentage points below it; measured number inside the range.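

In this assay, methyl in place of hydrogen on an aromatic carbon gives a number 2.9 percentage points higher from compound 1 to compound 4 (within the scatter), and the step can be set beside its counterpart on the other core: the same change on two cores in this assay, a number 2.9 percentage points higher (within the scatter) from compound 3 to compound 2 and a number 2.9 percentage points higher (within the scatter) from compound 1 to compound 4, 0 percentage points apart, within the scatter of two such steps

The change therefore carries from the core of compound 3 to the core of compound 1 with no readable difference between the two steps, though this rests on these two pairs alone. Both steps lie within the scatter, so neither core shows that the methyl alters growth inhibition, and the agreement says nothing about whether a larger effect would carry across the cores.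

Other groups at this place opposite the ring nitrogen, such as an amine, a methoxy group, a carboxylic acid or a longer chain such as ethyl, remain open. Also open, on these data alone, is whether the methyl step stays this small with a dimethylamino group in place of the saturated ring on the thiocarbonyl, or at lower concentrations than the one tested here.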